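A phenyl swap at the limit of the assay

A few compounds are considered here, and "the series" means these few. Any claim that something is new, unique, unknown or untested is made for them only; others in the source may bear on it.

In a functional assay on the whole organism (strain Kunming) with Mus musculus as the target, with a stated time of 0.5 h (a lower number here means that less compound is needed, a higher number that more compound is needed for the effect), compound 1 (`COc1ccccc1/C=C/C(=O)OC/C=C/c1cc(OC)c(OC)cc1OC`) gives > 300 mg/kg as a limit. Compound 2 (`COc1cc(OC)c(OC)cc1/C=C/COC(=O)/C=C/c1ccc(Br)cc1`) likewise gives > 300 mg/kg as a limit. Compound 3 (`COc1cc(OC)c(OC)cc1/C=C/COC(=O)/C=C/c1ccccc1C(F)(F)F`) stands at > 300 mg/kg as a limit too. Among the compounds with values here, the series so far offers only the limit of > 300 mg/kg in this assay, at which 3 of the 3 values shown sit, and no number. Compound 4 (`COc1cc(OC)c(OC)cc1/C=C/COC(=O)/C=C/c1cccc(Br)c1`) carries 3-bromophenyl in place of 2-(trifluoromethyl)phenyl on a double-bonded chain carbon bound to a double-bonded chain carbon. Of the measured steps, a step that the two limits leave unreadable from compound 2 to compound 3 and a step that the two limits leave unreadable from compound 1 to compound 2 and also a step that the two limits leave unreadable from compound 1 to compound 3 bear on it, yet none has a size to carry over. Hence a number no higher from compound 3 to compound 4 (the limit leaves the size open) is expected, with no direction beyond the scatter. Compound 4 is expected at an estimated 300 mg/kg within a range from 150 mg/kg to 600 mg/kg and may well turn out only as a limit.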

Compound 4, dose for half-maximal effect: 215 mg/kg
For compound 4 the middle estimate is 1.4-fold (0.14 log units) above the measured one; the range from low to high includes it.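

With 3-bromophenyl on a double-bonded chain carbon bound to a double-bonded chain carbon, compound 4 is the only compound shown that gives a number in this assay, while the others remain at a limit: the limit of > 300 mg/kg in this assay, at which 3 of the 4 values shown sit. The result reads as an at least 1.3-fold lower number from compound 3 to compound 4 (0.14 log units; that floor lies within the scatter), as an at least 1.3-fold lower number from compound 2 to compound 4 (0.14 log units; that floor lies within the scatter) and as an at least 1.3-fold lower number from compound 1 to compound 4 (0.14 log units; that floor lies within the scatter), so no ranking follows. The steps among the other three compounds cannot be read.

The compounds shown leave open whether 3-chlorophenyl or 3-aminophenyl at this place would give a number clearly beyond the scatter.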